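The compounds below may be only part of what the source reports. "The series", "measured", "known", "first", "only" and "open" are said of these compounds alone.

Measured compounds, with their results in an assay on HL-60 cells for agonist activity at vitamin D3 receptor (Homo sapiens), read by microscopy, with a stated time of 96 h; on this read-out lower numbers stand for an effect already at smaller amounts and higher numbers for an effect only at larger amounts of compound:
Compound 1, `C#CCNC(=O)c1ccc(C(CC)(CC)c2ccc(OCC(O)C(C)(C)C)c(C)c2)n1CC`, gives 240 nM.
Compound 2, `CCn1c(C(=O)Nc2ccc(OC(F)(F)F)cc2)ccc1C(CC)(CC)c1ccc(OCC(O)C(C)(C)C)c(C)c1`, gives only a limit, > 50000 nM.
Compound 3, `CCn1c(C(=O)Nc2cccc(C(F)(F)F)c2)ccc1C(CC)(CC)c1ccc(OCC(O)C(C)(C)C)c(C)c1`, gives only a limit, > 50000 nM.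

Compound 3 thus stands at the edge of what this assay can report: its number is a limit, not a measured concentration, and it shares this position with compound 2, as the limit of > 50000 nM in this assay, at which 2 of the 3 values shown sit, shows. Compound 1 is the only one of the three with a readable value.

Compound 4, `CCOc1ccc(NC(=O)c2ccc(C(CC)(CC)c3ccc(OCC(O)C(C)(C)C)c(C)c3)n2CC)cc1`, differs from compound 3 in one place: 4-ethoxyphenyl in place of 3-(trifluoromethyl)phenyl on an amide-type nitrogen. Going by the values given here, two measured steps bear on this change. Replacing the propargyl group on the amide-type nitrogen by either substituted phenyl group gave an at least 200-fold higher number from compound 1 to compound 2 (2.31 log units; beyond the scatter) and an at least 200-fold higher number from compound 1 to compound 3 (2.31 log units; beyond the scatter), so both phenyl-bearing amides sit at the limit. The step between those two, a step that the two limits leave unreadable from compound 2 to compound 3, cannot be sized. Compound 4 carries a third substituted phenyl group on the same amide-type nitrogen, and no such amide has yet given a readable number. Compound 4 is therefore expected to show a number no higher from compound 3 to compound 4 (the limit leaves the size open). The estimate for compound 4 is 50000 nM, with a range from 20000 nM to 200000 nM, and the result is most likely again only a limit.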

Compound 4, half-maximal effective concentration: 630 nM
For compound 4 the middle estimate is 79-fold (1.90 log units) above the measured one; measured number outside the range, below it.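

In this assay, a substituted phenyl group on the amide-type nitrogen does not by itself rule out a readable number: 4-ethoxyphenyl in place of 3-(trifluoromethyl)phenyl gives an at least 79-fold lower number from compound 3 to compound 4 (1.89 log units; beyond the scatter), and ethyl in place of trifluoromethyl on the oxygen, a change of that one group alone, gives an at least 79-fold lower number from compound 2 to compound 4 (1.89 log units; beyond the scatter). Compound 2 and compound 3 each stand at a limit rather than a number, so these two steps give only a minimum size: the limit of > 50000 nM in this assay, at which 2 of the 4 values shown sit. Against the propargyl amide, the 4-ethoxyphenyl amide shows only a modest change, a 2.6-fold higher number from compound 1 to compound 4 (0.42 log units; beyond the scatter), so among the four compounds the group carried by the phenyl ring separates the one readable phenyl amide from the two at the limit.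

Still open, going by these compounds, is whether a longer chain on that oxygen, such as propyl, or an amine in its place on the phenyl ring would keep a readable number. The step from compound 2 to compound 3 cannot be read, and the compounds shown do not separate the choice of group on the phenyl ring from where it sits.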